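Swapping a carbamate tail for a chloropyrimidine amide

This account rests on a few compounds, and the source may have more. Where it says the series, first, only, none or still open, it means among the compounds named here.

Of the compounds shown here, three sharing one core have been measured in a functional assay on isolated protein for inhibition of Glucose-dependent insulinotropic receptor (Rattus norvegicus), read by HTRF and cAMP accumulation; a lower number here means a smaller maximal response, a higher number a larger maximal response. Compound 1 `Cc1nc(S(C)(=O)=O)ccc1Oc1ncnc(OC2CCN(C(=O)OC(C)F)CC2)c1F` gives 68%, compound 2 `Cc1nc(S(C)(=O)=O)ccc1Oc1ncnc(OC2CCN(C(=O)OC3(C(F)(F)F)CCC3)CC2)c1F` gives 82%, and compound 3 `Cc1nc(S(C)(=O)=O)ccc1Oc1ncnc(OC2CCN(C(=O)SC(C)(C)C)CC2)c1F` gives 76%. Compound 2 shows the largest of the three numbers, but only its distance to compound 1 is clear: a number 14 percentage points higher from compound 1 to compound 2 (beyond the scatter), whereas a number 6 percentage points lower from compound 2 to compound 3 (within the scatter) and a number 8 percentage points higher from compound 1 to compound 3 (within the scatter) both stay within the scatter.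

Within the data shown here, the next compound, compound 4 `Cc1nc(S(C)(=O)=O)ccc1Oc1ncnc(OC2CCN(C(=O)c3ncc(Cl)cn3)CC2)c1F`, changes compound 2 at the same position as all the earlier steps: a group of 7 heavy atoms (4 carbon, 2 nitrogen, 1 chlorine; one six-membered aromatic ring with 2 hetero atoms) in place of a group of 9 heavy atoms (5 carbon, 1 oxygen, 3 fluorine; one four-membered non-aromatic ring of carbon only), on a carbonyl carbon. All three measured steps altered the group on this carbonyl carbon, and the largest of them moved the maximal response by a number 14 percentage points higher from compound 1 to compound 2 (beyond the scatter); the other two hardly moved it. Among the measured compounds shown here, none of those steps introduced an aromatic ring or a nitrogen-containing group at this place, so the data give no direct precedent for the 5-chloropyrimidin-2-yl group.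

The expectation is therefore a change of a number 10 percentage points lower from compound 2 to compound 4 (within the scatter), a step no larger than those seen so far and probably within the scatter. Compound 4 is estimated to reach 72% in this assay, with a range of 58% to 86%.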

Compound 4, largest response reached (reported as efficacy), in percent of the reference or control that the assay uses: 77%
Beside the measured number, compound 4's estimate is 5 percentage points below it; the measured number falls inside the stated range.
By their numbers in this assay, from the lowest: compounds 1, 3, 4 and 2 (each within the scatter of the next, the first and the last beyond it).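

In this assay the 5-chloropyrimidin-2-yl group changes the maximal response little, whichever group it replaces: a number 5 percentage points lower from compound 2 to compound 4 (within the scatter) and a number 1 percentage points higher from compound 3 to compound 4 (within the scatter) and a number 9 percentage points higher from compound 1 to compound 4 (within the scatter) are all printed as within the scatter. The carbonyl carbon on the amide-type nitrogen in a ring therefore accepts a six-membered aromatic ring with 2 hetero atoms, and compound 4 reaches 77% with neither the oxygen of compounds 1 and 2 nor the sulfur of compound 3 on that carbon. Among these compounds, compound 4 sits within the scatter of all three earlier compounds, so the only clear gap remains the one between compound 1 and compound 2, and the amide neither widens nor narrows the range seen with the earlier groups.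

The compounds shown leave open whether the chlorine matters, as they include no pyrimidin-2-yl without it and no phenyl, methoxy-bearing or nitrile-bearing ring at this carbonyl carbon, nor an amine that would turn the amide into a urea. No measurement at hand bears on why the response holds across these groups.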